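This account rests on a few compounds, and the source may have more. Where it says the series, first, only, none or still open, it means among the compounds named here.

Compound 1 `CC1CCN(C2CCN(S(=O)(=O)c3cccnc3Cl)CC2)CC1` gives > 5000 nM in a functional assay on DLD-1 cells (Homo sapiens) for antiproliferative activity, read by CellTiter-Glo, with a stated time of 72 h (on this read-out lower numbers stand for stronger inhibition and higher numbers for weaker inhibition), which is a limit of the assay rather than a number.
Compound 2 `CC1CCN(C2CCN(S(=O)(=O)c3ccc(OCc4ccccc4)cc3)CC2)CC1` gives 385 nM in this assay.
Compound 3 `CC1CCN(C2CCN(S(=O)(=O)c3ccc(C(C)C)cc3)CC2)CC1` gives 685 nM in this assay.

Among the compounds with values here, compound 3 and compound 2 are the only two with measured numbers, and the step of a 1.8-fold higher number from compound 2 to compound 3 (0.25 log units; within the scatter) leaves them within the scatter of each other. Compound 4 `CC1CCN(C2CCN(S(=O)(=O)c3ccc(C#N)cc3)CC2)CC1` differs from compound 3 by cyano in place of isopropyl on an aromatic carbon. Within the data shown here, the one measured step at this position, a 1.8-fold higher number from compound 2 to compound 3 (0.25 log units; within the scatter), was small, so a change at this place has so far moved the number little. The entering group is smaller than either earlier group at this place, and compound 1, which also lacks a large group there, is at a limit (the limit of > 5000 nM in this assay, at which 1 of the 3 values shown sits). A modest rise in number is therefore expected, a 2.2-fold higher number from compound 3 to compound 4 (0.34 log units; beyond the scatter), giving compound 4 an estimated 1500 nM in this assay, between 500 nM and 5000 nM.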

Compound 4, half-maximal inhibitory concentration: 2800 nM
The estimate for compound 4 lay 1.9-fold (0.27 log units) below the measured number; the range from low to high includes it.
By their numbers in this assay, from the lowest: compounds 2 and 3 (each within the scatter of the next); then compound 4. At a limit, above all of these: compound 1.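

Unlike the step between benzyloxy and isopropyl, which stayed within the scatter, cyano at this place gives a clear change in this assay: a 4.1-fold higher number from compound 3 to compound 4 (0.61 log units; beyond the scatter), and a 7.3-fold higher number from compound 2 to compound 4 (0.86 log units; beyond the scatter). The number here therefore does depend on which group sits on the ring. Compound 1 stands at a limit of the assay rather than a number, so its step, an at least 1.7-fold lower number from compound 1 to compound 4 (0.25 log units; that floor lies within the scatter), gives only a floor: the limit of > 5000 nM in this assay, at which 1 of the 4 values shown sits.

Going by these compounds, whether an amine, a carboxylic acid or a methoxy group at this place would sit nearer compound 2 or compound 4 stays open.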